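The source may report more compounds than this note shows. Statements on the series, on what has been measured and on what is new or still open speak of the compounds shown alone.

Series notes. Going by the values given here, compound 1 `COc1ccccc1N1C(=O)CSC1c1cc(F)cc(C(=O)O)c1` and compound 2 `COc1cccc(OC)c1N1C(=O)CSC1c1cccc(C(=O)NCCCCc2ccccc2)c1` are the two measured members so far. In a functional assay on HOS cells (Homo sapiens) for inhibition, read by CCK-8 assay, with a stated time of 72 h, tested at 1 uM (a lower number here means less inhibition, a higher number more inhibition at the concentration tested (going by the name of the read-out)), compound 1 gives 8%. In this assay compound 2 gives 80%, the highest of the two numbers; its nearest neighbour is compound 1, a number lower by a margin beyond the scatter. Among the compounds with values here, compound 1 and compound 2 differ in more than one place, so no single step between them is defined; their values show only that the pair spans a wide gap.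

Compound 3 `CC(F)(F)c1cccc(N2C(=O)CSC2c2cccc(C(=O)NCCCCc3ccccc3)c2)c1` is not yet measured in this assay. Relative to compound 2 it carries a group of 10 heavy atoms (8 carbon, 2 fluorine; one six-membered aromatic ring of carbon only) in place of a group of 10 heavy atoms (8 carbon, 2 oxygen; one six-membered aromatic ring of carbon only), on an amide-type nitrogen in a ring. Everything else on the shared core is kept. Within the data shown here, no measured pair isolates this change, so its size is unknown. Because compound 2 gives 80% with the rest of the structure identical, compound 3 is expected to stay in the upper range, and the expected step of a number 15 percentage points lower from compound 2 to compound 3 (beyond the scatter) is a modest one downward, possibly within the scatter. Compound 3 is thus estimated at 65%, with a range from 35% to 90%.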

Compound 3, a percentage reported as inhibition, at one concentration (the size of the read-out at that concentration, not a potency): 23%
For compound 3 the middle estimate is 42 percentage points above the measured one; the whole stated range lies above it.
By their numbers in this assay, from the lowest: compound 1; then compound 3; then compound 2.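

In this assay, going by these compounds alone, replacing the 2,6-dimethoxyphenyl group on the amide-type nitrogen in the ring with the group of 8 carbon and 2 fluorine atoms moves the reading a number 57 percentage points lower from compound 2 to compound 3 (beyond the scatter), the first step that can be tied to one place. At this single concentration, the inhibition read-out therefore depends strongly on the group at this position, even though the heavy-atom count, the six-membered aromatic carbon ring, the absence of hydrogen-bond donors and the absence of net charge stay the same, while hydrogen-bond acceptors go from 2 to 0. No available measurement bears on the reason for this step.

One exchange cannot show which feature of the 2,6-dimethoxyphenyl group accompanies the higher reading, and an unsubstituted phenyl group or a phenyl group with a single methoxy group on the same nitrogen would help separate the possibilities. The contribution of the other side of the molecule also remains unresolved, since compound 1 differs from compound 2 in more than one place, so a carboxylic acid, an amine or a shorter chain there would need comparison against a partner differing only at that site.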